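Acyl group variation across the shared core

The compounds below may be only part of what the source reports. "The series", "measured", "known", "first", "only" and "open" are said of these compounds alone.

Measured compounds:
compound 1 `CN(C(=O)NC(=O)c1c(F)cccc1F)c1nc(C(F)(F)F)c(C(=O)N/N=C/c2cccc(C(F)(F)F)c2)s1` — 21.6 ug/mL
compound 2 `CN(C(=O)NC(=O)c1ccc(Cl)cc1Cl)c1nc(C(F)(F)F)c(C(=O)N/N=C/c2cc(C(F)(F)F)cc(C(F)(F)F)c2)s1` — > 100 ug/mL, a limit
compound 3 `CN(C(=O)NC(=O)c1cccc(C(F)(F)F)c1)c1nc(C(F)(F)F)c(C(=O)N/N=C/c2cc(C(F)(F)F)cc(C(F)(F)F)c2)s1` — 5.34 ug/mL

In a functional assay on HeLa cells (Homo sapiens) for inhibition, read by MTT assay, with a stated time of 72 h (on this read-out lower numbers stand for stronger inhibition and higher numbers for weaker inhibition), compound 3 gives 5.34 ug/mL, the lowest of the two numbers; compound 1 gives 21.6 ug/mL. Compound 2 gives only the limit > 100 ug/mL (the limit of > 100 ug/mL in this assay, at which 1 of the 3 values shown sits). Going by the values given here, the one measured step, an at least 18-fold lower number from compound 2 to compound 3 (1.27 log units; beyond the scatter), shows the aryl group on the carbonyl carbon moving the read-out strongly. Compound 4 `CN(C(=O)NC(=O)c1c(F)cccc1F)c1nc(C(F)(F)F)c(C(=O)N/N=C/c2cc(C(F)(F)F)cc(C(F)(F)F)c2)s1` carries 2,6-difluorophenyl in place of 3-(trifluoromethyl)phenyl on a carbonyl carbon. Among the compounds with values here, compound 1 holds the same 2,6-difluorophenyl group with a different hydrazone aryl, so no measured step isolates this exchange; the values of compound 1 and compound 3 show a higher number with the difluoro group. Compound 4 is therefore expected to give a higher number, a 2.8-fold higher number from compound 3 to compound 4 (0.45 log units; beyond the scatter), estimated at 15 ug/mL (range 4 ug/mL to 60 ug/mL).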

Compound 4, half-maximal inhibitory concentration: 5.62 ug/mL
For compound 4 the middle estimate is 2.7-fold (0.43 log units) above the measured one, and the stated range covers the measured number.
By their numbers in this assay, from the lowest: compounds 3 and 4 (each within the scatter of the next); then compound 1. At a limit, above all of these: compound 2.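

On the carbonyl carbon, 2,6-difluorophenyl and 3-(trifluoromethyl)phenyl are not separated in this assay, with a 1.1-fold higher number from compound 3 to compound 4 (0.02 log units; within the scatter), so this position tolerates both groups in the compounds shown. Against 2,4-dichlorophenyl, the exchange gives an at least 17-fold lower number from compound 2 to compound 4 (1.25 log units; beyond the scatter), and the value of compound 2 is a limit, not a number: the limit of > 100 ug/mL in this assay, at which 1 of the 4 values shown sits. With 2,6-difluorophenyl held constant, trifluoromethyl in place of hydrogen on an aromatic carbon gives a 3.8-fold lower number from compound 1 to compound 4 (0.58 log units; beyond the scatter), the first measured step on the hydrazone aryl.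

From the compounds shown here alone, whether a plain phenyl or a methoxyphenyl on the carbonyl carbon would sit with compound 3 and compound 4 remains open. Also open, going by these compounds, is whether chlorine itself or the 2,4-dichloro arrangement sets compound 2 apart.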